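Chloro for Methyl on the Benzoyl Arm

The source may report more compounds than this note shows. Statements on the series, on what has been measured and on what is new or still open speak of the compounds shown alone.

The study compares two compounds built on a shared core. Compound 1 `Cc1ccc(-c2nn(-c3ccccc3)cc2-c2nc3ccccc3n2C(=O)c2ccncc2)cc1` carries a pyridinylcarbonyl on that core, and in an ADME assay on HEK-293T cells (Homo sapiens) for cytotoxicity, read by MTT assay, with a stated time of 24 h (a lower number here means that less compound is tolerated, a higher number that more compound is tolerated), compound 1 gives 154000 nM. Compound 2 `Cc1ccc(C(=O)n2c(-c3cn(-c4ccccc4)nc3-c3ccc(C(F)(F)F)cc3)nc3ccccc32)cc1` carries a (4-methylphenyl)carbonyl instead, and in this assay compound 2 gives 169000 nM. Compound 2 stands with the larger of the two numbers, but the gap to compound 1 lies within the scatter of repeated measurements, so the two cannot be ranked against each other.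

Compound 3 `O=C(c1ccc(Cl)cc1)n1c(-c2cn(-c3ccccc3)nc2-c2ccc(C(F)(F)F)cc2)nc2ccccc21` has not yet been measured. It differs from compound 2 in one place: chloro in place of methyl on an aromatic carbon. Going by the values given here, no measured pair in this set shows this change, so its effect is unknown. The step from compound 2 to compound 3 is expected to be a 1.1-fold lower number from compound 2 to compound 3 (0.05 log units; within the scatter), that is, no change beyond the scatter. Compound 3 is therefore estimated at 150000 nM, with a likely range from 75000 nM to 300000 nM.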

Compound 3, half-maximal cytotoxic concentration: 181000 nM
Compound 3: the middle estimate sits 1.2-fold (0.08 log units) below what was measured; low and high end bracket the measured number.
By their numbers in this assay, from the lowest: compounds 1, 2 and 3 (each within the scatter of the next).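

Chloro in place of methyl on the aromatic carbon para to a large group gives a 1.1-fold higher number from compound 2 to compound 3 (0.03 log units; within the scatter) in this assay, the first step in this set that changes only one place. Within the (4-methylphenyl)carbonyl and (4-chlorophenyl)carbonyl arms, then, this exchange leaves no readable difference between compound 2 and compound 3, which the earlier comparison of compound 1 and compound 2 could not show, as those two differ in more than one place. Nothing available here speaks to why the two compounds read alike.

The compounds shown leave open whether an amine or a carboxylic acid on this same aromatic carbon would move the number beyond the scatter. They also leave open whether chloro in place of methyl would read the same on another aromatic ring of the shared core.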